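The source may report more compounds than this note shows. Statements on the series, on what has been measured and on what is new or still open speak of the compounds shown alone.

Of the compounds shown here, three of one series have been measured in a functional assay on the whole organism (Tail, strain ICR) with Mus musculus as the target, in the tail flick test, with a stated time of 90 min, at a dose of 25 umol/kg by the oral route; a higher number here means a stronger effect of the compound at the dose given, a lower number a weaker effect. Compound 1 `CC(C)C[C@H](NC(=O)CN(c1nc(Cl)nc2[nH]cnc12)C1CC1)C(=O)OCc1ccccc1` gives 15.2% in this assay, which places it second highest of the three: compound 2 `CSCC[C@H](NC(=O)CN(c1nc(Cl)nc2[nH]cnc12)C1CC1)C(=O)O` gives 14%, a number within the scatter of compound 1, while compound 3 `CC(C)C[C@H](NC(=O)CN(c1nc(Cl)nc2[nH]cnc12)C1CC1)C(=O)O` gives 27%, beyond the scatter above it. The two steps seen so far are a number 11.8 percentage points higher from compound 1 to compound 3 (beyond the scatter) and a number 13 percentage points higher from compound 2 to compound 3 (beyond the scatter).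

Compound 4 `O=C(CN(c1nc(Cl)nc2[nH]cnc12)C1CC1)N[C@@H](CO)C(=O)OCc1ccccc1` differs from compound 1 in one place: hydroxy in place of isopropyl on a saturated chain carbon, two bonds along the chain from an amide-type nitrogen and a carbonyl carbon. The benzyl ester of compound 1 is kept in compound 4, so the step from compound 1 to compound 3 does not bear on it directly. The step from compound 2 to compound 3 is at the same place and moved this assay by a modest amount, but neither group there is hydroxy, so it gives no direction for this change. A step within the scatter, or a small one either way, is therefore expected, a number 3.2 percentage points lower from compound 1 to compound 4 (within the scatter). Compound 4 is estimated to give 12% in this assay, with a range from 3% to 28%.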

Compound 4, a percentage reported as activity, at one dose (the size of the read-out at that dose, not a potency): 34.5%
For compound 4 the middle estimate is 22.5 percentage points below the measured one; the whole stated range lies below it.
By their numbers in this assay, from the lowest: compounds 2 and 1 (each within the scatter of the next); then compounds 3 and 4 (each within the scatter of the next).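

In this assay, hydroxy in place of isopropyl on a saturated chain carbon, two bonds along the chain from an amide-type nitrogen and a carbonyl carbon, gives a number 19.3 percentage points higher from compound 1 to compound 4 (beyond the scatter) and shows that this position still responds beyond the scatter with the benzyl ester kept. For the compounds shown here, the earlier step at this place, a number 13 percentage points higher from compound 2 to compound 3 (beyond the scatter) on the free acid, involved neither hydroxy nor the benzyl ester, so only this new step shows an upward move on going from isobutyl to hydroxymethyl in the ester. No measurement offered here explains that rise.

As far as these compounds go, whether the same change would give a step of similar size on the free acid remains open. Also open, from the compounds shown here alone, is how an amine, a carboxylic acid or a longer hydroxyalkyl chain at this place would compare with hydroxymethyl.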